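Thiazolidinone Series: Methoxy Addition and the Cytotoxicity Limit

The compounds below may be only part of what the source reports. "The series", "measured", "known", "first", "only" and "open" are said of these compounds alone.

Working notes on the series in a functional assay on HCT-116 cells (Homo sapiens) for cytotoxicity, read by MTT assay, with a stated time of 72 h; on this read-out lower numbers stand for stronger inhibition and higher numbers for weaker inhibition. Compound 2 `O=C1CS/C(=N\c2csc(-c3ccccc3)c2)N1` carries the core without substituent on its phenyl ring. In this assay compound 2 gives only a limit, > 50000 nM. Compound 1 `COc1ccc(-c2cc(/N=C3/NC(=O)CS3)cs2)cc1` differs from it by methoxy in place of hydrogen on an aromatic carbon. In this assay compound 1 likewise gives only a limit, > 50000 nM. The step that the two limits leave unreadable from compound 2 to compound 1 is therefore not readable; the limit of > 50000 nM in this assay, at which 3 of the 3 values shown sit, is the reason it stays hidden. Compound 3 `COc1cccc(N2C(=O)CS/C2=N\c2csc(-c3ccc(Cl)cc3)c2)c1` has a different core; the difference between the two cores is not broken down here. In this assay compound 3 also gives only a limit, > 50000 nM. Compound 4 `COc1ccc(N2C(=O)CS/C2=N\c2csc(-c3ccc(Cl)cc3)c2)cc1OC` is compound 3 with methoxy in place of hydrogen on an aromatic carbon. This is the same kind of change as from compound 2 to compound 1, though here the place is ortho to a methoxy group as well as para to a large group. Among the measured compounds shown here, since every value so far sits at the limit, the step for compound 4 is expected to be about a step that the limit leaves unreadable from compound 3 to compound 4, with no basis for expecting a readable number. Compound 4 is thus estimated at 80000 nM, most likely again reported as a limit rather than a number.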

Compound 4, half-maximal inhibitory concentration: 49800 nM
For compound 4 the middle estimate is 1.6-fold (0.21 log units) above the measured one; the measured number falls inside the stated range.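

Among the compounds shown here, on the core of compound 3, methoxy in place of hydrogen on an aromatic carbon gives a number no higher from compound 3 to compound 4 (the limit leaves the size open) in this assay and compound 4 is the only compound here with a number. That step starts from a limit, and the same change from compound 2 to compound 1 has limits at both ends, so nothing shows that the change acts alike on the two cores. Neither step has a size, and the two cannot be compared: the limit of > 50000 nM in this assay, at which 3 of the 4 values shown sit.

The compounds shown leave open whether an amine or a carboxylic acid in place of methoxy would give a clearly lower number in this assay on this core. They also leave open what a longer chain in that place would do.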